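The source may hold more compounds than are shown below. What is called first, only, known or untested is meant among the compounds shown, and "the series" means these compounds.

Three compounds have so far been run in an ADME assay on liver for metabolic stability, with Liver microsome (Rattus norvegicus) as the target, read by LC-MS, using microsomes, with a stated time of 5 h; on this read-out higher numbers stand for fast clearance and lower numbers for slow clearance. Compound 1 `O[C@H](c1ccccn1)[C@@]1(c2ccc(Cl)c(Cl)c2)CCO1` gives 1000 mL/min/kg in this assay. Compound 2 `CN1CC(c2ccc(C(F)(F)F)cc2)(C(O)c2ccccn2)C1` gives 117 mL/min/kg in this assay, and compound 3 `O[C@H](c1ccccn1)[C@]1(c2cc(C(F)(F)F)ccn2)C[C@H](O)C1` gives 50 mL/min/kg there. Compound 2 thus stands second highest of the three: compound 3 sits closest to it, at a lower number that is beyond the scatter, while compound 1 lies furthest, higher by a margin well beyond the scatter. Compound 4 `OC(c1ccccn1)C1(c2ccc(C(F)(F)F)cc2)CNC1` has not yet been measured in this assay. It differs from compound 2 in one place: hydrogen in place of methyl on an amine nitrogen in a ring. Among the measured compounds shown here, no measured pair shows this change, so its direction rests on no observed step. A modest fall in clearance is expected for compound 4, a 1.7-fold lower number from compound 2 to compound 4 (0.22 log units; within the scatter), probably close to the edge of the scatter. Compound 4 is therefore estimated at 70 mL/min/kg, with a range from 30 mL/min/kg to 200 mL/min/kg.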

Compound 4, clearance: 50 mL/min/kg
Compound 4: the middle estimate sits 1.4-fold (0.15 log units) above what was measured; the range from low to high includes it.
By their numbers in this assay, from the lowest: compounds 3 and 4 (each within the scatter of the next); then compound 2; then compound 1.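

In this assay, among the compounds shown here, hydrogen in place of methyl on the amine nitrogen in the four-membered ring gives a 2.3-fold lower number from compound 2 to compound 4 (0.37 log units; beyond the scatter) and is the first observed step at this position. It shows that the clearance reading responds to this small change, though a single pair gives its direction on this one core only. Nothing available accounts for the step. On these data alone, whether an ethyl or an acetyl group on that nitrogen would give a higher or lower number remains open. So does whether the step would repeat on another core.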